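A few compounds are considered here, and "the series" means these few. Any claim that something is new, unique, unknown or untested is made for them only; others in the source may bear on it.

In an ADME assay on HEp-2 cells (Homo sapiens) for cytotoxicity (on this read-out higher numbers stand for lower toxicity in this test and lower numbers for higher toxicity in this test), compound 1 (`C=C(C)n1c(=O)n(Cc2nc3ccccc3n2CCC(C)C)c2ccccc21`) gives 24600 nM and compound 2 (`CC(C)CCn1c(Cn2c(=O)n(C(C)C)c3ccccc32)nc2c(CN)cccc21`) gives 7000 nM. Compound 3 (`CC(C)CCn1c(Cn2c(=O)n(C(C)C)c3ccccc32)nc2cc(CNC3CC3)ccc21`) gives 17200 nM, which lies within the scatter of compound 1 and clearly above compound 2, beyond the scatter.

Compound 4 (`CC(C)CCn1c(Cn2c(=O)n(C(C)C)c3ccccc32)nc2cc(CO)ccc21`) differs from compound 3 in one place: hydroxy in place of cyclopropylamino on a saturated chain carbon bound to an aromatic carbon. Hydroxy takes the place of cyclopropylamino on a saturated chain carbon bound to an aromatic carbon, so that (cyclopropylamino)methyl becomes hydroxymethyl.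

For the measured compounds named here, no measured pair isolates this change, so the data offer only indirect guidance. Compound 1 and compound 2 both lack the cyclopropylamino group, yet the evidence is mixed: compound 1 stands at 24600 nM, whereas compound 2 stands at 7000 nM. Only a small upward change is therefore expected, probably within the scatter, and the estimated step runs a 1.3-fold higher number from compound 3 to compound 4 (0.11 log units; within the scatter). In this assay, compound 4 is estimated at 22000 nM, with an expected range of 10000 nM to 50000 nM.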

Compound 4, half-maximal cytotoxic concentration: 31600 nM
Compound 4: the middle estimate sits 1.4-fold (0.16 log units) below what was measured, within the range that was stated.
By their numbers in this assay, from the lowest: compound 2; then compounds 3, 1 and 4 (each within the scatter of the next).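

For the compounds shown here, the pair gives the first direct reading of a change on a saturated chain carbon bound to an aromatic carbon: in this assay, replacing cyclopropylamino with hydroxy, so that (cyclopropylamino)methyl becomes hydroxymethyl, gives a 1.8-fold higher number from compound 3 to compound 4 (0.26 log units; within the scatter). That step lies within the scatter, so losing the three-membered ring and exchanging the nitrogen-linked group for an oxygen-linked one is not shown to alter the read-out, even though the counted hydrogen-bond donor and acceptor stay the same. Nothing available explains this result or bears on it.

The compounds shown leave open whether a carboxylic acid or a morpholine on this chain carbon would move the number beyond the scatter. They also leave open whether the same exchange would read alike on the core of compound 1.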